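Sulfonyl Amine Replaces Hydroxyethyl: Expected Gain in Binding

The compounds below may be only part of what the source reports. "The series", "measured", "known", "first", "only" and "open" are said of these compounds alone.

Compound 1, `Cc1ccc(S(=O)(=O)N(C)CC(C)C)cc1C#Cc1cc(Cl)ccc1OCC(=O)O`, gives 4.2 nM in an assay on CHO cells for displacement of a labelled ligand from prostaglandin D2 receptor 2 (Homo sapiens), read by scintillation counting; a higher number here means a weaker inhibitor, a lower number a stronger inhibitor.
Compound 2, `Cc1ccc(S(=O)(=O)CCO)cc1C#Cc1cc(Cl)ccc1OCC(=O)O`, gives 19 nM.
Compound 3, `O=C(O)COc1ccc(Cl)cc1C#Cc1cccnc1`, gives 117 nM.

Compound 2 holds the second highest of these three numbers, standing beyond the scatter from both compound 1 and compound 3. Compound 4, `Cc1ccc(S(=O)(=O)N(C)C(C)C)cc1C#Cc1cc(Cl)ccc1OCC(=O)O`, differs from compound 2 in one place: isopropyl(methyl)amino in place of 2-hydroxyethyl on a sulfonyl sulfur. Among the measured compounds shown here, one measured step bears on this change: a 4.5-fold higher number from compound 1 to compound 2 (0.66 log units; beyond the scatter). The move to compound 4 runs that step the other way, since the isopropyl(methyl)amino group entering is a near relative of the isobutyl(methyl)amino group of compound 1, so a lower number beyond the scatter is expected in this assay. Compound 4 is therefore estimated at 5 nM, within 2 nM to 14 nM. That estimate corresponds to an expected step of a 3.8-fold lower number from compound 2 to compound 4 (0.58 log units; beyond the scatter).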

Compound 4, inhibition constant: 3.8 nM
Compound 4: middle estimate off by 1.3-fold (0.12 log units), on the high side, and the stated range covers the measured number.
By their numbers in this assay, from the lowest: compounds 4 and 1 (each within the scatter of the next); then compound 2; then compound 3.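

Isopropyl(methyl)amino in place of 2-hydroxyethyl on a sulfonyl sulfur gives a 5.0-fold lower number from compound 2 to compound 4 (0.70 log units; beyond the scatter) in this assay and shows that the gain seen with compound 1 is not tied to the isobutyl chain. Isopropyl in place of isobutyl on the sulfonamide nitrogen gives a 1.1-fold lower number from compound 1 to compound 4 (0.04 log units; within the scatter) and leaves the two chains indistinguishable here. Nothing at hand explains the gap between these sulfonamides and compound 2.

Still open, from the compounds shown here alone, is how a much smaller nitrogen group such as ethyl would fare, or a piperidine ring that takes in the sulfonamide nitrogen.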